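The source may hold more compounds than are shown below. What is called first, only, known or untested is meant among the compounds shown, and "the series" means these compounds.

Working notes on the series.

Compound 2 `CCCn1c(N2CCN(C)CC2)nc2ccccc21` carries a propyl on the aromatic nitrogen of the shared core and, in a functional assay on ileum for inhibition of histamine H1 receptor (Cavia porcellus) (on this read-out higher numbers stand for weaker inhibition and lower numbers for stronger inhibition), compound 2 gives 380 nM. Within the data shown here, this is the highest of the three numbers measured so far. Compound 1 `CCCOCCn1c(N2CCN(C)CC2)nc2ccccc21` gives 20 nM in this assay. Compound 3 `CCCCOCCn1c(N2CCCN(C)CC2)nc2ccccc21` gives 10 nM in this assay. Compound 3 differs from compound 1 in several places. Among the measured compounds shown here, the single step measured in one place is the one from compound 1 to compound 2: a 19-fold higher number from compound 1 to compound 2 (1.28 log units; beyond the scatter).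

Compound 4 `CCCCCCCn1c(N2CCN(C)CC2)nc2ccccc21` differs from compound 2 by butyl in place of hydrogen on a saturated chain carbon, three bonds along the chain from an aromatic nitrogen. For the measured compounds named here, the only measured step that bears on this is the one from compound 1 to compound 2, where methyl in place of propoxy raised the number by a large margin; compound 4 restores length to the chain on the aromatic nitrogen, though without the propoxy group itself. Going by the values given here, the move from compound 2 to compound 4 is therefore expected to give a lower number in this assay, but by less than the full step seen between compound 1 and compound 2, since no measured pair tells how much of that step is owed to length alone. The expected step from compound 2 to compound 4 is a 3.2-fold lower number from compound 2 to compound 4 (0.50 log units; beyond the scatter). Compound 4 is estimated at 120 nM in this assay, within a range from 35 nM to 400 nM.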

Compound 4, half-maximal inhibitory concentration: 150 nM
For compound 4 the middle estimate is 1.3-fold (0.10 log units) below the measured one, within the range that was stated.
By their numbers in this assay, from the lowest: compounds 3 and 1 (each within the scatter of the next); then compound 4; then compound 2.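

Lengthening the chain alone is enough to move the number: with heptyl in place of propyl on the aromatic nitrogen, the step is a 2.5-fold lower number from compound 2 to compound 4 (0.40 log units; beyond the scatter) in this assay, so the carbon chain by itself counts for something at this position. The all-carbon chain does not stand in for the propoxy-bearing one, however, as pentyl in place of propoxy gives a 7.5-fold higher number from compound 1 to compound 4 (0.88 log units; beyond the scatter), a step beyond the scatter. The large step of a 19-fold higher number from compound 1 to compound 2 (1.28 log units; beyond the scatter) therefore splits into two measured parts, one seen on adding butyl to the propyl chain and one seen on exchanging propoxy for pentyl, and neither part alone covers it. Nothing at hand gives a reason for either part.

Open, from the compounds shown here alone, is whether the number keeps falling with chain length or turns at some point, which an all-carbon chain longer than heptyl or one between propyl and heptyl would test. Also open, going by these compounds, is whether the propoxy group can be matched by another group at the chain end, such as a hydroxyl or an amine.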